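Shifting the Fluorines and Nitro Group Around One Ring

The source may hold more compounds than are shown below. What is called first, only, known or untested is meant among the compounds shown, and "the series" means these compounds.

Compound 1 `Nc1nc(N)c(CCCN(Cc2ccc(NC(CCC(=O)O)C(=O)O)cc2)c2cc(F)ccc2[N+](=O)[O-])c(O)n1` was tested in a functional assay on CCRF-CEM cells (Homo sapiens) for cytotoxicity, in the absence of a further agent (on this read-out lower numbers stand for stronger inhibition and higher numbers for weaker inhibition), and gave only a limit of > 100000 nM, so no number is known for it. Compound 2 `CC(C)(C)OC(=O)CCC(Nc1ccc(CN(CCCc2c(N)nc(N)nc2O)c2ccc([N+](=O)[O-])c(F)c2F)cc1)C(=O)OC(C)(C)C` gives 24000 nM in this assay; of the two numbers available, it is the higher one. Among the measured compounds shown here, its nearest neighbour is compound 3 `CC(C)(C)OC(=O)CCC(Nc1ccc(CN(CCCc2c(N)nc(N)nc2O)c2ccc([N+](=O)[O-])c(F)c2[N+](=O)[O-])cc1)C(=O)OC(C)(C)C`, which gives 3200 nM, and the step of a 7.5-fold lower number from compound 2 to compound 3 (0.88 log units; beyond the scatter) is the only measured step in which a single change was made. Compound 4 `CC(C)(C)OC(=O)CCC(Nc1ccc(CN(CCCc2c(N)nc(N)nc2O)c2cc(F)c(F)cc2[N+](=O)[O-])cc1)C(=O)OC(C)(C)C` has not yet been measured. It differs from compound 2 by 4,5-difluoro-2-nitrophenyl in place of 2,3-difluoro-4-nitrophenyl on an amine nitrogen: the same atoms are kept, and only their arrangement around the ring changes. The measured step from compound 2 to compound 3 replaced one group by another, which is a different kind of change, so it does not directly match the present rearrangement; it does show that altering the pattern of groups on this ring can move the number beyond the scatter. With no closer comparison available, no direction can be favoured. Compound 4 is therefore expected to give an estimated 20000 nM, with a range from 6000 nM to 70000 nM. The step this estimate implies is expected to be a 1.2-fold lower number from compound 2 to compound 4 (0.08 log units; within the scatter).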

Compound 4, half-maximal inhibitory concentration: 4800 nM
Estimate against measurement, compound 4: 4.2-fold (0.62 log units) above, outside the stated range (below it).
By their numbers in this assay, from the lowest: compounds 3 and 4 (each within the scatter of the next); then compound 2. At a limit, above all of these: compound 1.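

Moving from 2,3-difluoro-4-nitrophenyl to 4,5-difluoro-2-nitrophenyl on the amine nitrogen gives a 5.0-fold lower number from compound 2 to compound 4 (0.70 log units; beyond the scatter) in this assay, with no atom added or removed. Among the compounds shown here, the only earlier measured change on this ring swapped one group for another, giving a 7.5-fold lower number from compound 2 to compound 3 (0.88 log units; beyond the scatter); the new result shows that rearranging the same groups is by itself enough to move the number beyond the scatter, so the pattern around the ring matters here and not only which groups it carries. Nothing measured here explains why this rearrangement changes the number.

Going by these compounds, with only these two arrangements to compare, it remains open whether the step follows the new place of the nitro group or the new places of the two fluorines, since both differ between the rings. Also open, on these data alone, is how the 4,5-difluoro-2-nitrophenyl ring would respond if one of its fluorines gave way to a chlorine or a nitrile, which would show whether this arrangement keeps its lower number when the groups themselves change.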